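Fluorine on a Second Core: an Expected Shift

A few compounds are considered here, and "the series" means these few. Any claim that something is new, unique, unknown or untested is made for them only; others in the source may bear on it.

The measured compounds so far:
Compound 1 `C1=NCC(CC2Cc3ccccc3C2)N1` gives 39.8 nM in a functional assay for binding affinity to Norepinephrine transporter (Rattus norvegicus), read by radioligand binding, in the presence of a further agent that is not named here; on this read-out lower numbers stand for stronger inhibition and higher numbers for weaker inhibition.
Compound 2 `Fc1cccc2c1CC(CC1CN=CN1)C2` gives 100 nM in this assay.
Compound 3 `C1=NCC(Cc2cc3ccccc3o2)N1` gives 63.1 nM in this assay.

Compound 4 `Fc1ccc2oc(CC3CN=CN3)cc2c1` has not yet been measured in this assay. It differs from compound 3 in one place: fluoro in place of hydrogen on an aromatic carbon. The same kind of change separates compound 1 from compound 2: fluoro in place of hydrogen on an aromatic carbon. That step gave a 2.5-fold higher number from compound 1 to compound 2 (0.40 log units; beyond the scatter). The two places are not the same, though: in compound 2 the fluorine sits ortho to a fused ring and meta to a fused ring, while in compound 4 it sits meta to a fused ring and para to a fused ring. How the core of compound 3 differs from the core of compound 1 is not broken down here; the two values lie within the usual scatter of each other.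

Because compound 2 showed a 2.5-fold higher number from compound 1 to compound 2 (0.40 log units; beyond the scatter), a similar but somewhat smaller step is expected for compound 4, namely a 1.7-fold higher number from compound 3 to compound 4 (0.24 log units; within the scatter). Compound 4 is therefore estimated at 110 nM, with a likely range from 50 nM to 250 nM.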

Compound 4, inhibition constant: 794 nM
For compound 4 the middle estimate is 7.2-fold (0.86 log units) below the measured one; the measured number lies above the stated range.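

Fluoro in place of hydrogen on an aromatic carbon gives a 13-fold higher number from compound 3 to compound 4 (1.10 log units; beyond the scatter) in this assay, a large loss of inhibition. On both cores the change moved the number the same way, upward, but the size of the step did not carry over: the same change on two cores in this assay, a 2.5-fold higher number (0.40 log units; beyond the scatter) from compound 1 to compound 2 and a 13-fold higher number (1.10 log units; beyond the scatter) from compound 3 to compound 4, 5.0-fold (0.70 log units) apart, beyond the scatter of two such steps

So the earlier step pointed the right way for compound 4 but was a poor guide to how far the number would move, and two pairs cannot show whether this is a general pattern. In these pairs the fluorine also sits in a different place on a different core, so the data cannot separate the effect of the core from that of the fluorine's place.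

The compounds shown leave open how large the step would be with the fluorine on another aromatic carbon of the core of compound 3. They also leave open whether a chloro or methoxy group on the aromatic carbon used in compound 4 would raise the number as far as fluoro does.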